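This account rests on a few compounds, and the source may have more. Where it says the series, first, only, none or still open, it means among the compounds named here.

Compound 1, with structure `CC1=C(/C=C/C(=O)/C=C/c2ccc(Cl)cc2)C(C)(C)CCC1`, was tested in a functional assay on IMR-32 cells (Homo sapiens) for cytotoxicity, read by sulforhodamine B assay, with a stated time of 48 h (a lower number here means a stronger inhibitor, a higher number a weaker inhibitor), where compound 1 gives 52300 nM. Two other compounds sharing the same core give context. Compound 2, `COc1ccccc1/C=C/C(=O)/C=C/C1=C(C)CCCC1(C)C`, gives 19200 nM in this assay, and compound 3, `COc1cc(/C=C/C(=O)/C=C/C2=C(C)CCCC2(C)C)cc(OC)c1OC`, gives 55500 nM. Among these three numbers compound 1 holds the second highest. Its nearest neighbour is compound 3, whose number lies within the usual scatter of compound 1, so the two cannot be told apart. Its furthest neighbour is compound 2, whose number is lower by a margin that lies beyond the scatter.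

Compound 4, `CC1=C(/C=C/C(=O)/C=C/c2cccnc2)C(C)(C)CCC1`, has not yet been measured in this assay. It differs from compound 1 in one place: pyridin-3-yl in place of 4-chlorophenyl on a double-bonded chain carbon bound to a double-bonded chain carbon. Among the compounds with values here, no pair of measured compounds shows this kind of change, so no measured step can guide the expectation directly. Since compounds 2 and 3 show that changes at the aryl end move the number only modestly in this set, the step from compound 1 to compound 4 is expected to be small and not beyond the scatter, which is what a 1.1-fold higher number from compound 1 to compound 4 (0.06 log units; within the scatter) represents. On that basis compound 4 is estimated to give about 60000 nM in this assay, with a likely range from 25000 nM to 150000 nM.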

Compound 4, half-maximal inhibitory concentration: 25300 nM
For compound 4 the middle estimate is 2.4-fold (0.38 log units) above the measured one, and the stated range covers the measured number.
By their numbers in this assay, from the lowest: compounds 2 and 4 (each within the scatter of the next); then compounds 1 and 3 (each within the scatter of the next).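

In this assay, the step from 4-chlorophenyl to pyridin-3-yl on a double-bonded chain carbon bound to a double-bonded chain carbon gives a 2.1-fold lower number from compound 1 to compound 4 (0.32 log units; beyond the scatter) and thus lies beyond the scatter. This is the first single-place step shown at this position, and it establishes that the aryl group here can be exchanged with a modest gain in inhibition rather than a loss, with the chlorine gone and a ring nitrogen counted as a hydrogen-bond acceptor in the new group. No accompanying measurement accounts for the step, so what lies behind it remains unexplained.

The compounds shown leave open whether the step follows from the loss of the chlorine, from the ring nitrogen, or from both together, a question that an unsubstituted phenyl group at this place would help to separate. They also leave open whether pyridin-2-yl or pyridin-4-yl would move the number in the same direction, and how a phenyl ring carrying an amine or a carboxylic acid would behave at this place.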